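The compounds below may be only part of what the source reports. "The series", "measured", "known", "first", "only" and "open" are said of these compounds alone.

Measured compounds:
- compound 1, `CC(=O)c1ccc(OCCCN2CCN(c3ncccn3)CC2)cc1`: 53.2 nM
- compound 2, `CC(=O)c1ccc(OCCCCN2CCN(c3ccccn3)CC2)cc1`: 24.1 nM
- compound 3, `CCC(C)(C)c1ccc(OCCCCN2CCN(c3cccnc3)CC2)cc1`: 3.23 nM

These three compounds were tested in a functional assay on L5178Y cells (Mus musculus) for antiproliferative activity, read by MTT assay; on this read-out higher numbers stand for weaker inhibition and lower numbers for stronger inhibition. Compound 1 gives 53.2 nM, the highest number of the three, which here means the weakest inhibition among them. Compound 2 gives 24.1 nM and compound 3 gives 3.23 nM; both of these differ from compound 1 in more than one place, so no single change can be read from them.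

Compound 4, `CC(=O)c1ccc(OCCCN2CCN(c3ccncc3)CC2)cc1`, has not yet been measured. It differs from compound 1 in one place: pyridin-4-yl in place of pyrimidin-2-yl on an amine nitrogen in a ring. The rest of the structure is unchanged. Among the compounds with values here, no measured pair shows the effect of this particular change on its own, so the expectation rests on the modest spread seen among the three measured compounds. The step from compound 1 to compound 4 in this assay is expected to be small, a 1.3-fold lower number from compound 1 to compound 4 (0.12 log units; within the scatter), and may well lie within the scatter. Compound 4 is therefore estimated at 40 nM, with a plausible range from 15 nM to 110 nM.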

Compound 4, half-maximal inhibitory concentration: 42.3 nM
Beside the measured number, compound 4's estimate is 1.1-fold (0.02 log units) below it; the measured number falls inside the stated range.
By their numbers in this assay, from the lowest: compound 3; then compounds 2, 4 and 1 (each within the scatter of the next, the first and the last beyond it).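

In this assay, putting pyridin-4-yl in place of pyrimidin-2-yl on the amine nitrogen in the ring gives a 1.3-fold lower number from compound 1 to compound 4 (0.10 log units; within the scatter) and so cannot be told apart from the usual scatter of repeated measurements. Within the data shown here, this is the first single-place comparison in the set. The earlier compounds shown here differ from one another in more than one place. At this position, going from a ring with two nitrogens and two hydrogen-bond acceptors to one with a single nitrogen and a single acceptor leaves the antiproliferative read-out about where it was, and nothing measured here offers an explanation.

The compounds shown leave open whether a phenyl ring, with no ring nitrogen at all, would fit this place equally well. They also leave open whether the same swap would give so small a step on a longer chain, such as a hexyl linker.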